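Losing One Ester Group From Compound 3

The compounds below may be only part of what the source reports. "The series", "measured", "known", "first", "only" and "open" are said of these compounds alone.

Three compounds share one core, and each carries a matching pair of ester groups. In a functional assay on KBVIN cells (Homo sapiens) for inhibition, read by sulforhodamine B assay, with a stated time of 72 h (a higher number here means a weaker inhibitor of growth, a lower number a stronger inhibitor of growth), compound 1 (`C=C1CC[C@@H]2[C@](C)(COC(=O)c3cnccn3)[C@H](OC(=O)c3cnccn3)CC[C@@]2(C)[C@@H]1/C=C/C1=CCOC1=O`) gives 9190 nM and compound 2 (`C=C1CC[C@@H]2[C@](C)(COC(=O)CCN(C)C)[C@H](OC(=O)CCN(C)C)CC[C@@]2(C)[C@@H]1/C=C/C1=CCOC1=O`) gives 31700 nM on the same scale. Compound 3 (`C=C1CC[C@@H]2[C@](C)(COC(=O)CCCCC3CCSS3)[C@H](OC(=O)CCCCC3CCSS3)CC[C@@]2(C)[C@@H]1/C=C/C1=CCOC1=O`) gives 12900 nM in this assay and cannot be told apart from compound 1, while compound 2 sits clearly higher, which means weaker growth inhibition than compound 3.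

Compound 4 (`C=C1CC[C@@H]2[C@](C)(COC(=O)CCCCC3CCSS3)[C@H](O)CC[C@@]2(C)[C@@H]1/C=C/C1=CCOC1=O`) has not been measured yet. Its change from compound 3 (a hydrogen atom in place of a group of 11 heavy atoms (8 carbon, 1 oxygen, 2 sulfur; one five-membered non-aromatic ring with 2 hetero atoms), on an oxygen on a saturated carbon) puts a hydrogen atom in place of the group with the five-membered non-aromatic ring, on an oxygen on a saturated carbon, and the other ester stays.

Among the measured compounds shown here, none of the measured compounds shows what losing one ester does, so any forecast here is loose. For the measured compounds named here, the only anchor is compound 3 at 12900 nM in this assay and the remaining ester is the same as in that compound. The step expected is a 1.3-fold lower number from compound 3 to compound 4 (0.11 log units; within the scatter) and no shift beyond the scatter is expected. For compound 4 the estimated value is 10000 nM (expected range 3500 nM to 28000 nM).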

Compound 4, concentration for 50% growth inhibition: > 30000 nM
Compound 4: no number, only a limit; the forecaster's own chance of this, stated with the estimate: 5%; at least 3.0-fold (0.47 log units) between middle value and limit.
By their numbers in this assay, from the lowest: compounds 1 and 3 (each within the scatter of the next); then compound 2.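

Putting a hydrogen atom in place of the group with the five-membered non-aromatic ring, on an oxygen on a saturated carbon, gives in this assay an at least 2.3-fold higher number from compound 3 to compound 4 (0.36 log units; beyond the scatter), which means weaker growth inhibition. The earlier compounds shown here carry matching pairs of esters, so they could not show what a single ester at this position is worth; this step shows that growth inhibition here depends on keeping an ester on this oxygen, and that the other ester alone does not hold it at the earlier level. The reading for compound 4 is a limit and not a number, so the step has a minimum size but no known full size: the limit of > 30000 nM in this assay, at which 1 of the 4 values shown sits.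

On these data alone, it remains open whether the ester with the ring is needed in particular, or whether a small acetate ester or a methyl ether on this oxygen would serve as well. Also open, as far as these compounds go, is what happens in the mirror case, with a free hydroxyl on the other oxygen and the ester kept at this position.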